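Chlorophenyl piperazine oxindoles in the forced swim test

The source may hold more compounds than are shown below. What is called first, only, known or untested is meant among the compounds shown, and "the series" means these compounds.

The series shares one core, as in compound 1 `CCC1(CCCCN2CCN(c3ccc(Cl)cc3)CC2)C(=O)Nc2cc(F)ccc21`, compound 2 `CCC1(CCCCN2CCN(c3cccc(Cl)c3)CC2)C(=O)Nc2ccccc21` and compound 3 `CCC1(CCCCN2CCN(c3cccc(Cl)c3)CC2)C(=O)Nc2cc(F)c(Cl)cc21`, and differs in the chlorophenyl group on the piperazine and in the substitution of the aromatic ring of the core. In a functional assay on the whole organism (strain NMRI) with Mus musculus as the target, in the forced swim test, with stated times of 30 min, 4 min and 6 min (on this read-out lower numbers stand for an effect already at smaller amounts and higher numbers for an effect only at larger amounts of compound), compound 1 reaches only a limit of the assay, > 10 mg/kg. In this assay compound 2 likewise stops at a limit, > 10 mg/kg. For compound 3 this assay gives "not determined" (no result reported). Compound 2 therefore stands at a limit and not at a number; the pattern across the measured set is the limit of > 10 mg/kg in this assay, at which 2 of the 3 values shown sit.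

Compound 4 `CCC1(CCCCN2CCN(c3ccc(Cl)cc3)CC2)C(=O)Nc2ccccc21` is not yet measured. It differs from compound 2 by 4-chlorophenyl in place of 3-chlorophenyl on an amine nitrogen in a ring. Among the measured compounds shown here, no measured pair follows this change, so the size of the step rests on compound 1 and compound 2 alone, which both sit at a limit. Compound 4 is expected to stay near that limit as well, since compound 1, carrying the same 4-chlorophenyl, gives > 10 mg/kg. Compound 4 is thus estimated at 15 mg/kg, within 5 mg/kg to 40 mg/kg, with a step that the limit leaves unreadable from compound 2 to compound 4 expected to be no more than the usual scatter, most likely reported as a limit again.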

Compound 4, minimum effective dose: > 10 mg/kg
Compound 4: a limit, no number; the forecaster's own chance of this, stated with the estimate: 70%; the middle value lies beyond the limit too.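

In this assay compound 4 gives > 10 mg/kg, a limit and not a number. The steps joining compound 4 to compound 1 and to compound 2 cannot be read: the limit of > 10 mg/kg in this assay, at which 3 of the 4 values shown sit.

The compounds shown leave open whether 4-chlorophenyl and 3-chlorophenyl differ at all in this assay, and whether hydrogen and fluoro on the aromatic carbon do.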